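A few compounds are considered here, and "the series" means these few. Any claim that something is new, unique, unknown or untested is made for them only; others in the source may bear on it.

Measured so far:
compound 1, `O=C(Nc1cccc(-n2cc(-c3ccncc3)c(-c3ccc(Cl)c(O)c3)n2)c1)Nc1ccc(Cl)c(Cl)c1`: 1180 nM
compound 2, `COc1cc(-c2nn(-c3cccc(NC(=O)Nc4ccc(Cl)c(C(F)(F)F)c4)c3)cc2-c2ccncc2)ccc1Cl`: 760 nM

Both compounds were tested in a functional assay on MDA-MB-231 cells (Homo sapiens) for inhibition, read by sulforhodamine B assay, with a stated time of 48 h; a lower number here means a stronger inhibitor of growth, a higher number a weaker inhibitor of growth. Compound 2 gives the lower of the two numbers, but its gap to compound 1 falls within the scatter, so the two cannot be ranked. Compound 3, `O=C(Nc1cccc(-n2cc(-c3ccncc3)c(-c3ccc(Cl)c(O)c3)n2)c1)Nc1ccc(Cl)c(C(F)(F)F)c1`, has not yet been measured. It differs from compound 2 by hydrogen in place of methyl on an oxygen on an aromatic ring. Among the measured compounds shown here, no pair of measured compounds separated by this single change is available, so the size of the step is unknown. With a change this small, no step beyond the scatter is expected: a 1.2-fold higher number from compound 2 to compound 3 (0.07 log units; within the scatter). Compound 3 is estimated at 900 nM, with a range from 350 nM to 2500 nM.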

Compound 3, concentration for 50% growth inhibition: 488 nM
Estimate against measurement, compound 3: 1.8-fold (0.27 log units) above; low and high end bracket the measured number.
By their numbers in this assay, from the lowest: compounds 3, 2 and 1 (each within the scatter of the next, the first and the last beyond it).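

In this assay, going from methoxy to hydroxy gives a 1.6-fold lower number from compound 2 to compound 3 (0.19 log units; within the scatter) so at this oxygen, hydrogen can stand in place of methyl without a change that can be told from the scatter. Trifluoromethyl in place of chloro on an aromatic carbon, with the hydroxy kept, gives a 2.4-fold lower number from compound 1 to compound 3 (0.38 log units; beyond the scatter) which is a modest step but a readable one. Nothing measured here explains either step. As far as these compounds go, whether the trifluoromethyl step also holds with methoxy in place of hydroxy stays open. So does the effect of an amine or an ethoxy group in place of the hydroxy.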